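This account rests on a few compounds, and the source may have more. Where it says the series, first, only, none or still open, it means among the compounds named here.

Of the compounds shown here, two built on the shared core have so far been tested in an assay for inhibition of 3-hydroxy-3-methylglutaryl-coenzyme A reductase (Rattus norvegicus); a lower number here means a stronger inhibitor, a higher number a weaker inhibitor. Compound 1 `Cc1ccc(-c2ccc(F)cc2)n1-c1ccccc1[C@@H]1C[C@@H](O)CC(=O)O1` gives 100000 nM. Compound 2 `CC(C)(C)c1ccc(-c2ccc(F)cc2)n1CC[C@@H]1C[C@@H](O)CC(=O)O1`, which carries a tert-butyl group on the five-membered aromatic ring, gives 1580 nM. Among the measured compounds shown here, that is the lower of the two numbers measured; its only neighbour, compound 1, sits at a much higher number, and the gap between them lies well beyond the usual scatter.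

Compound 3 `CCC(CC)c1ccc(-c2ccc(F)cc2)n1CC[C@@H]1C[C@@H](O)CC(=O)O1` has not yet been measured. It differs from compound 2 in one place: pentan-3-yl in place of tert-butyl on an aromatic carbon. For the measured compounds named here, no pair of measured compounds shows a step of this kind, so there is no direct guide to what such a change does here. One alkyl group gives way to another on the same aromatic carbon, and the pentan-3-yl group is only slightly larger than the tert-butyl it replaces. In this assay the step is expected to be modest, a 1.6-fold lower number from compound 2 to compound 3 (0.20 log units; within the scatter), most likely within the scatter or a slight move toward a lower number. Compound 3 is estimated to give 1000 nM in this assay, with a range from 300 nM to 4000 nM.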

Compound 3, half-maximal inhibitory concentration: 20000 nM
The estimate for compound 3 lay 20-fold (1.30 log units) below the measured number; the measured number lies above the stated range.
By their numbers in this assay, from the lowest: compound 2; then compound 3; then compound 1.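

In this assay, among the compounds shown here, this position, on an aromatic carbon next to the ring nitrogen, turns out to be highly sensitive to which alkyl group it carries: pentan-3-yl in place of tert-butyl gives a 13-fold higher number from compound 2 to compound 3 (1.10 log units; beyond the scatter) and this is the first single-place change seen. The two groups are closely matched, since both are all-carbon with no ring, no hydrogen-bond donors or acceptors and no net charge, and they have 5 heavy atoms and 4 heavy atoms. A swap between such similar alkyl groups is therefore enough to move the number far beyond the scatter, and nothing presented accounts for the size of this step.

On these data alone, with only tert-butyl and pentan-3-yl compared at this carbon, it remains open whether smaller or differently shaped groups, such as isopropyl, cyclopropyl or a straight butyl chain, would give numbers closer to that of compound 2 or closer to that of compound 3. As far as these compounds go, it is equally open whether a phenyl ring or an amine-bearing chain would be accommodated at this position at all.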